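Cytotoxicity of Purine Benzylamines in BJ Cells

The compounds below may be only part of what the source reports. "The series", "measured", "known", "first", "only" and "open" are said of these compounds alone.

Compound 1 `COc1ccc(CNc2ncnc3c2ncn3C2CCCCO2)c(OC)c1` carries the shared core with two methoxy groups on its benzyl ring. In an ADME assay on BJ cells (Homo sapiens) for cytotoxicity, read by MTT assay, with a stated time of 72 h (on this read-out lower numbers stand for stronger inhibition and higher numbers for weaker inhibition), compound 1 gives only a limit, > 25000 nM. Compound 2 `COc1cc(OC)c(OC)cc1CNc1ncnc2c1ncn2C1CCCCO1` differs by methoxy in place of hydrogen on an aromatic carbon. In this assay compound 2 also reaches only a limit, > 100000 nM. The step that the two limits leave unreadable from compound 1 to compound 2 is therefore not readable: compound 1 sits at the limit of > 25000 nM in this assay, at which 1 of the 3 values shown sits, while compound 2 sits at the limit of > 100000 nM in this assay, at which 1 of the 3 values shown sits. Compound 3 `COc1ccc(OC)c(CNc2ncnc3c2ncn3C2CCCO2)c1` has a different core; the difference between the two cores is not broken down here. In this assay compound 3 gives a limit too, > 50000 nM, which is the limit of > 50000 nM in this assay, at which 1 of the 3 values shown sits. Compound 4 `COc1cc(OC)c(OC)cc1CNc1ncnc2c1ncn2C1CCCO1` differs from compound 3 by methoxy in place of hydrogen on an aromatic carbon, the same kind of change as before, though here the new group sits meta to a methoxy group and para to a large group rather than meta to a large group and para to a methoxy group. With every neighbour at a limit, compound 4 is expected to show a step that the limit leaves unreadable from compound 3 to compound 4 in this assay. Compound 4 is thus estimated at 80000 nM, between 25000 nM and 300000 nM.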

Compound 4, half-maximal inhibitory concentration: > 100000 nM
Compound 4 was reported as a limit; the forecaster's own chance of this, stated with the estimate: 85%; middle value at least 1.2-fold (0.09 log units) away from the limit.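

Compound 4, like compound 2 and compound 3, gives only a limit in this assay, so neither step to compound 4 can be read. The compounds shown leave open at what concentration any of them would inhibit these cells.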